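This account rests on a few compounds, and the source may have more. Where it says the series, first, only, none or still open, it means among the compounds named here.

Compound 1 `Nc1nc(N)c2c(-c3ccsc3)cn([C@@H]3O[C@H](CO)[C@@H](O)[C@H]3O)c2n1`: > 20000 nM
Compound 2 `COc1nc(N)nc2c1c(-c1cccs1)cn2[C@@H]1O[C@H](CO)[C@@H](O)[C@H]1O`: > 20000 nM

In a functional assay on HCT-116 cells (Homo sapiens), read by MTT assay, with a stated time of 72 h (a lower number here means a stronger inhibitor, a higher number a weaker inhibitor), compound 1 reports only a limit, > 20000 nM. In this assay compound 2 likewise reports only a limit, > 20000 nM. Compound 2 thus stands at the edge of what the assay resolves, as both values shown do (the limit of > 20000 nM in this assay, at which 2 of the 2 values shown sit), and no number sets it apart from compound 1.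

Compound 3 `Nc1nc(N)c2c(-c3cccs3)cn([C@@H]3O[C@H](CO)[C@@H](O)[C@H]3O)c2n1` is not yet measured. It differs from compound 2 by amino in place of methoxy on an aromatic carbon. For the measured compounds named here, no step between measured compounds is known, so nothing here calibrates the change. The expected step that the limit leaves unreadable from compound 2 to compound 3 is set at none beyond the scatter, since compound 2 gives only a limit, > 20000 nM, and the change is small. Compound 3 is estimated at 25000 nM, with a range from 8000 nM to 80000 nM, and a limit rather than a number is the more likely report.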

Compound 3, half-maximal inhibitory concentration: > 20000 nM
Compound 3 was reported as a limit (the forecaster's own chance of this, stated with the estimate: 85%); the middle value does not contradict the limit.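

In this assay compound 3 gives > 20000 nM, a limit and not a number. The steps to it from compound 1 and compound 2 therefore cannot be read: the limit of > 20000 nM in this assay, at which 3 of the 3 values shown sit. Still open, from the compounds shown here alone, is whether amino versus methoxy, or thiophen-2-yl versus thiophen-3-yl, changes potency on the shared core.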